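Methylimidazole in place of pyrazole on the shared core

The compounds below may be only part of what the source reports. "The series", "measured", "known", "first", "only" and "open" are said of these compounds alone.

Compound 2 `c1ccc(-c2cn[nH]c2)c(NCC2=NCCN2)c1` gives 79.4 nM in an in vitro functional assay on cells (Fibroblast) for agonist activity at Alpha-1B adrenergic receptor (Homo sapiens) (on this read-out higher numbers stand for an effect only at larger amounts of compound and lower numbers for an effect already at smaller amounts), the larger of the two numbers recorded, though its gap to compound 1 `Cn1ncnc1-c1ccccc1NCC1=NCCN1`, which gives 39.8 nM, lies within the scatter. For the measured compounds named here, the only measured step, a 2.0-fold higher number from compound 1 to compound 2 (0.30 log units; within the scatter), was of that size. Compound 3 `Cn1ccnc1-c1ccccc1NCC1=NCCN1` differs from compound 2 by 1-methyl-1H-imidazol-2-yl in place of 1H-pyrazol-4-yl on an aromatic carbon. Since compound 1 already carries a methylated azole at the same place with 39.8 nM, no step beyond the scatter is expected, a 1.6-fold lower number from compound 2 to compound 3 (0.20 log units; within the scatter). Compound 3 is therefore estimated at 50 nM, with a range from 15 nM to 170 nM.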

Compound 3, half-maximal effective concentration: 39.8 nM
Beside the measured number, compound 3's estimate is 1.3-fold (0.10 log units) above it, and the stated range covers the measured number.
By their numbers in this assay, from the lowest: compounds 1, 3 and 2 (each within the scatter of the next).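

Exchanging the azole on this aromatic carbon gave a 2.0-fold lower number from compound 2 to compound 3 (0.30 log units; within the scatter) and also no change at the digits printed from compound 1 to compound 3 (within the scatter) in this assay. For the compounds shown here, the 1-methyl-1H-imidazol-2-yl group thus replaced both the 1H-pyrazol-4-yl group, with 1 hydrogen-bond donor, and the 1-methyl-1H-1,2,4-triazol-5-yl group with no step leaving the scatter, so these three azoles cannot be told apart at this position. Nothing available explains why they read alike. Going by these compounds, whether an aminomethyl group or a carboxylic acid on this carbon would produce a step beyond the scatter remains open.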